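This account rests on a few compounds, and the source may have more. Where it says the series, first, only, none or still open, it means among the compounds named here.

Compounds measured in an assay on microsomes from liver for inhibition of 3-hydroxy-3-methylglutaryl-coenzyme A reductase (Rattus norvegicus); a higher number here means a weaker inhibitor, a lower number a stronger inhibitor:
compound 1, `CC(C)c1c(C(=O)N(C)Cc2ccccc2)nn(-c2ccc(F)cc2)c1OC[C@@H](O)C[C@@H](O)CC(=O)O` — 5.2 nM
compound 2, `CC(C)c1c(C(=O)N2CCCC2c2ccccc2)nn(-c2ccc(F)cc2)c1OC[C@@H](O)C[C@@H](O)CC(=O)O` — 14 nM

Compound 2 shows the highest number of the two; its nearest neighbour is compound 1, the step being a 2.7-fold higher number from compound 1 to compound 2 (0.43 log units; beyond the scatter). Among the measured compounds shown here, that single step, 2-phenylpyrrolidin-1-yl in place of benzyl(methyl)amino on a carbonyl carbon, is the only measured change at this position.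

Compound 3, `CC(C)c1c(C(=O)N2CCCCC2)nn(-c2ccc(F)cc2)c1OC[C@@H](O)C[C@@H](O)CC(=O)O`, is not yet measured. It differs from compound 2 in one place: piperidin-1-yl in place of 2-phenylpyrrolidin-1-yl on a carbonyl carbon. For the measured compounds named here, the entering group keeps a saturated ring on the amide nitrogen but carries no six-membered aromatic ring, and no measured step covers loss of that ring. Going by the values given here, the step from compound 1 to compound 2 gives the only guide and is modest, so a modest-to-moderate rise in the number is expected for compound 3, with the estimated step of a 2.9-fold higher number from compound 2 to compound 3 (0.46 log units; beyond the scatter). Compound 3 is therefore expected to give about 40 nM in this assay, within 12 nM to 150 nM.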

Compound 3, half-maximal inhibitory concentration: 47 nM
Estimate against measurement, compound 3: 1.2-fold (0.07 log units) below, within the range that was stated.
By their numbers in this assay, from the lowest: compound 1; then compound 2; then compound 3.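

In this assay the amide group on the carbonyl carbon now spans a wider range: a 3.4-fold higher number from compound 2 to compound 3 (0.53 log units; beyond the scatter) with piperidin-1-yl in place of 2-phenylpyrrolidin-1-yl, and a 9.0-fold higher number from compound 1 to compound 3 (0.96 log units; beyond the scatter) with piperidin-1-yl in place of benzyl(methyl)amino. Both steps lie beyond the scatter, and among these three compounds the two amides carrying a six-membered aromatic ring give the lower numbers, with none going against this. Nothing measured here accounts for these steps.

From the compounds shown here alone, it remains open whether the aromatic ring itself tracks the number, as a phenyl group placed on the piperidine ring would help to show. A small dimethylamino group or a morpholin-4-yl group on the same carbonyl carbon could also show how far the number moves with other groups lacking that ring.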